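One halogen exchanged in a series at the assay limit

The source may hold more compounds than are shown below. What is called first, only, known or untested is meant among the compounds shown, and "the series" means these compounds.

Compound 1 `COc1cc(/C=C/C(=O)c2sc(Nc3ccc(Cl)c(Cl)c3)nc2C)cc(OC)c1OC`: > 25000 nM
Compound 2 `Cc1nc(Nc2ccc(Cl)c(Cl)c2)sc1C(=O)/C=C/c1ccc(Cl)cc1`: > 25000 nM
Compound 3 `COc1cccc(/C=C/C(=O)c2sc(Nc3ccccc3C)nc2C)c1`: > 25000 nM

In a functional assay on NCI-H460 cells (Homo sapiens) for cytotoxicity, read by MTT assay (a higher number here means a weaker inhibitor, a lower number a stronger inhibitor), compound 1 gives > 25000 nM, which is a limit of the assay and not a number. Compound 2 gives > 25000 nM, likewise a limit. Compound 3 gives > 25000 nM, again a limit. Compound 1 therefore stands exactly where every value shown stands: the limit of > 25000 nM in this assay, at which 3 of the 3 values shown sit. Among the compounds with values here, no step between two measured compounds is available, so nothing here shows how any single change moves this read-out.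

Compound 4 `COc1cc(/C=C/C(=O)c2sc(Nc3ccc(F)c(Cl)c3)nc2C)cc(OC)c1OC` differs from compound 1 in one place: fluoro in place of chloro on an aromatic carbon. The exchange is small, and the shared core, the enone linker and the trimethoxyphenyl group of compound 1 are untouched. With all three measured compounds at the limit, the step from compound 1 to compound 4 is expected to be a step that the limit leaves unreadable from compound 1 to compound 4, no step beyond the scatter, most likely ending at the same limit. Compound 4 is accordingly estimated at 30000 nM, with a range from 10000 nM to 100000 nM, and a measurement will have to say whether a number emerges at all.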

Compound 4, half-maximal inhibitory concentration: 6310 nM
Beside the measured number, compound 4's estimate is 4.8-fold (0.68 log units) above it, and the stated range ends above it.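

Fluoro in place of chloro, turning the 3,4-dichlorophenyl group into the 3-chloro-4-fluorophenyl group, gives in this assay an at least 3.9-fold lower number from compound 1 to compound 4 (0.59 log units; beyond the scatter), so a single exchange of one halogen on an aromatic carbon is enough to bring the read-out off the limit while the rest of the molecule stays unchanged. The value of compound 1, > 25000 nM, is a limit of the assay and not a number, so this step is known only as a minimum. Compound 4, with 6310 nM, is the only compound shown that gives a number: the limit of > 25000 nM in this assay, at which 3 of the 4 values shown sit.

Going by these compounds, it stays open whether the same exchange would act likewise on compound 2. On these data alone, it is also open how a bromo, a nitrile or a trifluoromethyl group at this position would read.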